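Bromo in place of hydrogen on the phenyl of compound 2

The compounds below may be only part of what the source reports. "The series", "measured", "known", "first", "only" and "open" are said of these compounds alone.

Two analogues share the core and the lipoate-bearing side chain. Compound 1 `CC(=O)c1cc2ccc(OCCCCCn3cc(CNC(=O)CCCCC4CCSS4)nn3)cc2oc1=O` gives 28.9% in a functional assay on PC-12 cells (Rattus norvegicus) for cytotoxicity, read by MTT assay, with stated times of 3 h and 2 h, tested at 0.1 uM; a lower number here means a weaker effect, a higher number a stronger effect of the compound at the concentration tested. Compound 2 `O=C(CCCCC1CCSS1)NCc1cn(CCCCCOc2ccc3cc(-c4ccccc4)c(=O)oc3c2)nn1` gives 35.5% in this assay. The step of a number 6.6 percentage points higher from compound 1 to compound 2 (within the scatter) is the only measured one, and the two numbers are not separated from one another: compound 2 stands with the larger of the two readings, but within the scatter of compound 1.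

Compound 3 `O=C(CCCCC1CCSS1)NCc1cn(CCCCCOc2ccc3cc(-c4ccc(Br)cc4)c(=O)oc3c2)nn1` carries the change (bromo in place of hydrogen on an aromatic carbon). Among the compounds with values here, no measured step touches this position; the one measured step, from acetyl to phenyl, changes a different part and was itself within the scatter, so it gives no direction for a change on the phenyl. The expectation is therefore a step of a number 0.5 percentage points higher from compound 2 to compound 3 (within the scatter) in this assay, not beyond the scatter. Compound 3 is expected to give about 36% in this assay, within 22% to 50%.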

Compound 3, a percentage reported as activity, at one concentration (the size of the read-out at that concentration, not a potency): 41.8%
Beside the measured number, compound 3's estimate is 5.8 percentage points below it; the measured number falls inside the stated range.
By their numbers in this assay, from the lowest: compounds 1, 2 and 3 (each within the scatter of the next, the first and the last beyond it).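

In this assay, bromo in place of hydrogen on the phenyl gives a number 6.3 percentage points higher from compound 2 to compound 3 (within the scatter), so this change alone does not separate the two compounds. Within the data shown here, the 4-bromophenyl in place of acetyl gives a number 12.9 percentage points higher from compound 1 to compound 3 (beyond the scatter), the first step to lie beyond the scatter, whereas the plain phenyl in place of acetyl stayed within it. Nothing available here gives a reason for either step.

Still open, on these data alone, is whether a different group at this place on the phenyl, such as an amine or a carboxylic acid, would read apart from compound 3. Also open, as far as these compounds go, is whether a longer chain between the core and the triazole-linked side chain would shift the reading, and, since each reading comes from a single concentration, how potency compares across the series.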